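Swapping 3,4-dichlorophenyl for 2,3,4-trifluorophenyl on a shared core

A few compounds are considered here, and "the series" means these few. Any claim that something is new, unique, unknown or untested is made for them only; others in the source may bear on it.

In a functional assay on K562 cells (Homo sapiens) for antiproliferative activity, with a stated time of 72 h (on this read-out higher numbers stand for weaker inhibition and lower numbers for stronger inhibition), compound 1 `COc1cccc(CNc2ncnc3c2ncn3[C@@H]2O[C@H](CO)[C@@H](O)[C@H]2O)c1` gives only a limit, > 166000 nM. Among the compounds with values here, compound 2 `OC[C@H]1O[C@@H](n2cnc3c(NCc4ccc(Cl)cc4Cl)ncnc32)[C@H](O)[C@@H]1O` gives 106000 nM, while compound 3 `OC[C@H]1O[C@@H](n2cnc3c(NCc4ccc(Cl)c(Cl)c4)ncnc32)[C@H](O)[C@@H]1O` gives 10800 nM, the lowest number so far. Compound 4 `OC[C@H]1O[C@@H](n2cnc3c(NCc4ccc(F)c(F)c4F)ncnc32)[C@H](O)[C@@H]1O` is not yet measured; it carries 2,3,4-trifluorophenyl in place of 3,4-dichlorophenyl on a saturated chain carbon bound to a nitrogen on an aromatic ring. Three measured steps change this same group. The step of an at least 15-fold lower number from compound 1 to compound 3 (1.18 log units; beyond the scatter) is large and a 9.8-fold lower number from compound 2 to compound 3 (0.99 log units; beyond the scatter) is modest, whereas the floor of an at least 1.5-fold lower number from compound 1 to compound 2 (0.19 log units; that floor lies within the scatter) lies within the scatter. None exchanges chlorine for fluorine, so the expectation is loose. A modest rise is expected, an estimated 3.7-fold higher number from compound 3 to compound 4 (0.57 log units; beyond the scatter). Compound 4 is estimated at 40000 nM, with an expected range of 10000 nM to 160000 nM.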

Compound 4, half-maximal inhibitory concentration: > 166000 nM
Compound 4: only a limit was reported (the forecaster's own chance of this, stated with the estimate: 20%); at least 4.1-fold (0.61 log units) between middle value and limit.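

In this assay, the place on a saturated chain carbon bound to a nitrogen on an aromatic ring proves sensitive to exchanging chlorine for fluorine, with 2,3,4-trifluorophenyl replacing 3,4-dichlorophenyl giving an at least 15-fold higher number from compound 3 to compound 4 (1.18 log units; beyond the scatter). Against the 2,4-dichlorophenyl group, only a floor can be given, an at least 1.5-fold higher number from compound 2 to compound 4 (0.19 log units; that floor lies within the scatter). Compound 1 and compound 4 both end at a limit, so the step between them cannot be read: the limit of > 166000 nM in this assay, at which 2 of the 4 values shown sit.

Going by these compounds, what 3,4-difluorophenyl or 3,4-dibromophenyl would give at this place stays open. The change shown therefore does not separate the kind of halogen from the number of halogens or their placement.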